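Ethoxycarbonyl in place of phenyl on a carbonyl carbon

A few compounds are considered here, and "the series" means these few. Any claim that something is new, unique, unknown or untested is made for them only; others in the source may bear on it.

Compound 3 `COc1cc(/C=C/C(=O)c2cccc(NC(=O)c3ccccc3)c2)ccc1O` stands lowest of the three compounds measured in a functional assay on HUVEC cells (Homo sapiens) for inhibition, tested at 10 ug/mL (on this read-out higher numbers stand for a stronger effect at the one concentration tested and lower numbers for a weaker effect), at 69%. Compound 1 `COc1cc(/C=C/C(=O)c2cccc(NC(=O)c3cccs3)c2)ccc1O` gives 90%, and compound 2 `CCCC(=O)Nc1cccc(C(=O)/C=C/c2ccc(O)c(OC)c2)c1` gives 87%. The two steps that end in phenyl are both losses: a number 21 percentage points lower from compound 1 to compound 3 (beyond the scatter) and a number 18 percentage points lower from compound 2 to compound 3 (beyond the scatter), whereas a number 3 percentage points lower from compound 1 to compound 2 (within the scatter). Compound 4 `CCOC(=O)C(=O)Nc1cccc(C(=O)/C=C/c2ccc(O)c(OC)c2)c1` differs from compound 3 by ethoxycarbonyl in place of phenyl on a carbonyl carbon. Among the compounds with values here, the steps that bear on this change are the two in which phenyl entered on that carbonyl carbon, each a modest loss, so leaving phenyl seems more likely to raise than to lower the number in this assay; ethoxycarbonyl itself has no measured precedent, so the size is uncertain. Compound 4 is therefore expected to move by a number 9 percentage points higher from compound 3 to compound 4 (within the scatter). The estimate for compound 4 is 78%, within a range from 60% to 92%.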

Compound 4, a percentage reported as inhibition, at one concentration (the size of the read-out at that concentration, not a potency): 66%
Compound 4: the middle estimate sits 12 percentage points above what was measured; the range from low to high includes it.
By their numbers in this assay, from the lowest: compounds 4 and 3 (each within the scatter of the next); then compounds 2 and 1 (each within the scatter of the next).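

In this assay, ethoxycarbonyl on this carbonyl carbon does not recover the loss seen with phenyl (a number 3 percentage points lower from compound 3 to compound 4 (within the scatter)). It also falls short of the other two groups (a number 21 percentage points lower from compound 2 to compound 4 (beyond the scatter); a number 24 percentage points lower from compound 1 to compound 4 (beyond the scatter)), so the four groups form two pairs: propyl with thiophen-2-yl, and phenyl with ethoxycarbonyl. No measured evidence accounts for this split. The split pairs a ring with a chain on each side, so neither a ring nor a chain alone tracks the read-out here. On these data alone, whether an amine or a carboxylic acid at this carbonyl carbon, or a chain longer than propyl, would join the higher pair or the lower pair remains open.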